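Cyano for Methoxy: Expecting Compound 4's Growth Inhibition

The compounds below may be only part of what the source reports. "The series", "measured", "known", "first", "only" and "open" are said of these compounds alone.

Compound 1 `COc1cccc2sc(NC(=O)c3ccc(C(F)(F)F)cc3)nc12` gives only the limit > 10 ug/mL in a functional assay on SK-HEP1 cells (Homo sapiens) for antiproliferative activity, read by sulforhodamine B assay; on this read-out lower numbers stand for stronger inhibition of growth and higher numbers for weaker inhibition of growth.
Compound 2 `COc1ccc(C(=O)Nc2nc3c(OC)cccc3s2)cc1` gives 2.11 ug/mL in this assay.
Compound 3 `COc1ccccc1NC(=O)Nc1nc2ccc(F)cc2s1` gives only the limit > 10 ug/mL in this assay.

Among the compounds with values here, compound 2 thus holds the only number; the other two results sit at the limit of > 10 ug/mL in this assay, at which 2 of the 3 values shown sit. Compound 4 `COc1cccc2sc(NC(=O)c3ccc(C#N)cc3)nc12` differs from it by cyano in place of methoxy on an aromatic carbon, cyano in place of methoxy. Within the data shown here, the single measured step, an at least 4.7-fold lower number from compound 1 to compound 2 (0.67 log units; beyond the scatter), swapped trifluoromethyl for methoxy at this same position and was at least modest. Cyano is neither of those groups, so no step bears directly on the change; the reverse direction suggests a weaker number, perhaps back to a limit. Compound 4 is therefore expected to give about 6 ug/mL, between 2 ug/mL and 15 ug/mL, a step of a 2.8-fold higher number from compound 2 to compound 4 (0.45 log units; beyond the scatter).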

Compound 4, concentration for 50% growth inhibition: > 10 ug/mL
Compound 4 was reported as a limit; the forecaster's own chance of this, stated with the estimate: 40%; middle value at least 1.6-fold (0.22 log units) away from the limit.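

Cyano in place of methoxy on the aromatic carbon para to a large group gave an at least 4.7-fold higher number from compound 2 to compound 4 (0.67 log units; beyond the scatter), so among the three groups shown at this place, only the methoxy of compound 2 gives a number in this assay. The result for compound 4, > 10 ug/mL, is a limit. The step from compound 1 to compound 4 cannot be read, so cyano and trifluoromethyl cannot be ranked against each other.

Going by these compounds, whether an amine or a hydroxyl at this place would give a number, as methoxy does, stays open. On these data alone, how far compound 1 and compound 4 lie past their limits also stays open.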